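This account rests on a few compounds, and the source may have more. Where it says the series, first, only, none or still open, it means among the compounds named here.

Compound 1 `O=C(CCCCc1[nH]c2ccccc2c1C1=C(Br)C(=O)NC1=O)Nc1ccccc1`: 2.56
Compound 2 `Cc1ccc(NC(=O)CCCc2[nH]c3ccccc3c2C2=C(Br)C(=O)NC2=O)cc1`: 2.56

In a physicochemical assay for lipophilicity (a lower number here means a more polar compound, a higher number a more lipophilic compound), compound 2 stands level with compound 1; the step of no change at the digits printed from compound 1 to compound 2 (within the scatter) lies within the scatter. Compound 3 `Cc1cccc(NC(=O)CCCc2[nH]c3ccccc3c2C2=C(Br)C(=O)NC2=O)c1` differs from compound 2 by 3-methylphenyl in place of 4-methylphenyl on an amide-type nitrogen, the two having the same atoms joined differently. Within the data shown here, only one measured step, no change at the digits printed from compound 1 to compound 2 (within the scatter), is available, and it concerns a different change, so no measured step moves a methyl from one ring position to another. The step of no change at the digits printed from compound 2 to compound 3 (within the scatter) is therefore expected to stay within the scatter. The estimate for compound 3 is 2.56, with a range of 2.3 to 2.82.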

Compound 3, partition coefficient: 2.56
Estimate against measurement, compound 3: no gap at the digits printed; low and high end bracket the measured number.
By their numbers in this assay, from the lowest: compounds 1, 2 and 3 (each within the scatter of the next).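

In this assay, among these compounds, moving the methyl from 4-methylphenyl to 3-methylphenyl on the amide-type nitrogen gives no change at the digits printed from compound 2 to compound 3 (within the scatter), the first measured step at this position for a change that joins the same atoms differently. The (3-methylphenyl)carbamoyl change likewise gives no change at the digits printed from compound 1 to compound 3 (within the scatter), level with the (4-methylphenyl)carbamoyl change. Nothing measured here offers an explanation for this result. The compounds shown leave open how a methoxy group, a chlorine atom or a carboxylic acid on this ring would read, and how a longer chain would compare.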